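From 2-methoxyethyl to isopropyl on the shared core

The source may hold more compounds than are shown below. What is called first, only, known or untested is meant among the compounds shown, and "the series" means these compounds.

Measured so far in an ADME assay on RAW264.7 cells (Mus musculus) for cytotoxicity, read by MTT assay, with a stated time of 24 h; a higher number here means that more compound is tolerated, a lower number that less compound is tolerated
compound 1 `CC/C=C\C[C@H]1C(=O)C=C[C@H]1CC(=O)OCCC` gives 35 uM
compound 2 `CC/C=C\C[C@H]1C(=O)C=C[C@H]1CC(=O)OCCOC` gives 160 uM

Of these two, compound 2 stands highest (160 uM), with compound 1 lower by more than the scatter. Compound 3 `CC/C=C\C[C@H]1C(=O)C=C[C@H]1CC(=O)OC(C)C` carries isopropyl in place of 2-methoxyethyl on an oxygen next to a carbonyl group. Going by the values given here, one measured step bears on this change (a 4.6-fold higher number from compound 1 to compound 2 (0.66 log units; beyond the scatter)), where methoxy took the place of methyl. The new change also removes that methoxy, so a step of similar size in the opposite direction, beyond the scatter, is expected (a 4.0-fold lower number from compound 2 to compound 3 (0.60 log units; beyond the scatter)). Compound 3 is expected to give (40 uM), within an estimated range (17 uM to 95 uM).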

Compound 3, half-maximal toxic concentration: 58 uM
Compound 3: the middle estimate sits 1.5-fold (0.16 log units) below what was measured; low and high end bracket the measured number.
By their numbers in this assay, from the lowest: compounds 1 and 3 (each within the scatter of the next); then compound 2.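

In this assay, isopropyl in place of 2-methoxyethyl on an oxygen next to a carbonyl group gives a 2.8-fold lower number from compound 2 to compound 3 (0.44 log units; beyond the scatter), so a second chain without the methoxy also falls short of compound 2. Isopropyl in place of propyl gives a 1.7-fold higher number from compound 1 to compound 3 (0.22 log units; within the scatter), so the branched and straight chains cannot be told apart here. Of these three compounds, only compound 2, with its methoxy, stands apart. Nothing measured here explains this difference. Still open, going by these compounds, is whether a 2-hydroxyethyl or 2-aminoethyl chain would stand with compound 2 or with the other two compounds.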